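The source may hold more compounds than are shown below. What is called first, only, known or untested is meant among the compounds shown, and "the series" means these compounds.

Measured compounds:
compound 1, `O=C(c1ccc(NC2CCCCC2)cc1)C1CC1c1ccc(Cl)cc1`: 196 ug/mL
compound 2, `CCCCN(CCCC)c1ccc(C(=O)C2CC2c2ccc(Cl)cc2)cc1`: 431 ug/mL
compound 3, `CCCCCCCCNc1ccc(C(=O)C2CC2c2ccc(Cl)cc2)cc1`: 214 ug/mL

All three were run in an ADME assay on Vero cells (Chlorocebus sabaeus) for cytotoxicity, with a stated time of 72 h; on this read-out higher numbers stand for lower toxicity in this test and lower numbers for higher toxicity in this test. Compound 1 has the lowest of the three numbers in this assay, with compound 3 lying within the scatter of it and compound 2 the furthest away. The two steps from compound 1 are a 1.1-fold higher number from compound 1 to compound 3 (0.04 log units; within the scatter) and a 2.2-fold higher number from compound 1 to compound 2 (0.34 log units; beyond the scatter). Compound 4, `O=C(c1ccc(NCCn2ccnc2)cc1)C1CC1c1ccc(Cl)cc1`, differs from compound 1 by 2-(1H-imidazol-1-yl)ethyl in place of cyclohexyl on a nitrogen on an aromatic ring. Neither measured step replaces the cyclohexyl with a group carrying an aromatic ring with hetero atoms, so neither speaks directly to this change; the closest comparison, a 1.1-fold higher number from compound 1 to compound 3 (0.04 log units; within the scatter), swaps the cyclohexyl for a chain and stays within the scatter. The step expected for compound 4 in this assay is therefore a 1.1-fold higher number from compound 1 to compound 4 (0.05 log units; within the scatter), nothing beyond the scatter. Compound 4 is estimated at 220 ug/mL, with a range of 100 ug/mL to 450 ug/mL.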

Compound 4, half-maximal cytotoxic concentration: 243 ug/mL
The estimate for compound 4 lay 1.1-fold (0.04 log units) below the measured number, and the stated range covers the measured number.
By their numbers in this assay, from the lowest: compounds 1, 3, 4 and 2 (each within the scatter of the next, the first and the last beyond it).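

In this assay, 2-(1H-imidazol-1-yl)ethyl is tolerated on the nitrogen on an aromatic ring, with a 1.2-fold higher number from compound 1 to compound 4 (0.09 log units; within the scatter), while the comparison with the octyl chain gives a 1.1-fold higher number from compound 3 to compound 4 (0.06 log units; within the scatter) and that with dibutylamino gives a 1.8-fold lower number from compound 2 to compound 4 (0.25 log units; within the scatter). A group with a five-membered aromatic ring and hydrogen-bond acceptors therefore sits within the scatter of all three earlier compounds on this read-out. No available evidence bears on this result.

As far as these compounds go, whether a carboxylic acid or a morpholine at the end of the ethyl chain would stay within this scatter remains open. So does the effect of a longer chain carrying 1H-imidazol-1-yl.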